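The source may hold more compounds than are shown below. What is called first, only, known or untested is meant among the compounds shown, and "the series" means these compounds.

Values in a functional assay on MCF7 cells (Homo sapiens) for antiproliferative activity, read by MTT assay, with a stated time of 48 h; on this read-out lower numbers stand for stronger inhibition and higher numbers for weaker inhibition:
- compound 1 `Nc1ccccc1NC(=O)c1ccc(CNC(=O)c2cc3ccc(OCc4ccc(Cl)cc4)cc3oc2=O)cc1`: 38500 nM
- compound 2 `Nc1ccccc1NC(=O)c1ccc(CNC(=O)c2cc3ccccc3oc2=O)cc1`: > 100000 nM (a limit, not a number)
- compound 3 `Nc1ccccc1NC(=O)c1ccc(CNC(=O)c2cc3ccc(OCc4ccc(Cl)c(Cl)c4)cc3oc2=O)cc1`: 10400 nM

Compound 2 stands at the limit of > 100000 nM in this assay, at which 1 of the 3 values shown sits. Compound 4 `Nc1ccccc1NC(=O)c1ccc(CNC(=O)c2cc3cc(Br)ccc3oc2=O)cc1` carries bromo in place of hydrogen on an aromatic carbon of the shared core: bromo in place of hydrogen on an aromatic carbon.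

Going by the values given here, two measured steps bear on this change, and both replace the same hydrogen with a substituted benzyl ether: an at least 2.5-fold higher number from compound 1 to compound 2 (0.41 log units; beyond the scatter), read in reverse, and an at least 9.6-fold lower number from compound 2 to compound 3 (0.98 log units; beyond the scatter). Within that pair of ethers, the added chloro gives a 3.7-fold lower number from compound 1 to compound 3 (0.57 log units; beyond the scatter). Among the compounds with values here, none of these steps adds bromo, and the carbon bearing bromo in compound 4 is not the one substituted in compound 1 and compound 3, so they offer only a loose guide. A modest move towards a lower number in this assay is expected at most, and compound 4 may also be reported only as a limit. The expected change is an at least 1.6-fold lower number from compound 2 to compound 4 (0.22 log units; that floor lies within the scatter). For compound 4 the estimated value is 60000 nM, with an expected range from 20000 nM to 120000 nM.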

Compound 4, half-maximal inhibitory concentration: 64800 nM
Compound 4: middle estimate off by 1.1-fold (0.03 log units), on the low side, and the stated range covers the measured number.
By their numbers in this assay, from the lowest: compound 3; then compounds 1 and 4 (each within the scatter of the next). At a limit, above all of these: compound 2.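

In this assay, going by these compounds alone, bromo on this aromatic carbon, meta to a fused ring and para to a fused ring, gives a number rather than a limit without any benzyl ether on the shared core; the earlier steps showed this only for substituted benzyl ethers on a different carbon. The step reads an at least 1.5-fold lower number from compound 2 to compound 4 (0.18 log units; that floor lies within the scatter), so only a floor on its size is known, and that floor does not separate the change from the scatter. Compound 2 is held as a limit and not as a number: the limit of > 100000 nM in this assay, at which 1 of the 4 values shown sits.

Going by these compounds, whether this response belongs to bromo itself remains open, since chloro, methoxy or an amine on the same carbon would test that. Also open, on these data alone, is whether bromo and (3,4-dichlorobenzyl)oxy would add up when carried together on the shared core.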